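Anilide series on a shared core: fluoro for hydrogen

A few compounds are considered here, and "the series" means these few. Any claim that something is new, unique, unknown or untested is made for them only; others in the source may bear on it.

In a functional assay on HCT-116 cells (Homo sapiens) for antiproliferative activity, read by MTT assay, with a stated time of 48 h (on this read-out higher numbers stand for weaker inhibition and lower numbers for stronger inhibition), compound 1 `COc1cc(-c2nnc(SCC(=O)c3ccc(Cl)cc3)n2N)cc(OC)c1OC` gives 7500 nM.
In this assay compound 2 `COc1cc(-c2nnc(SCC(=O)c3cccc(Br)c3)n2N)cc(OC)c1OC` gives 5320 nM.
In this assay compound 3 `COc1cc(-c2nnc(SCC(=O)Nc3ccccc3)n2N)cc(OC)c1OC` gives 1730 nM.

Compound 3 holds the lowest number of the three: a 4.3-fold lower number from compound 1 to compound 3 (0.64 log units; beyond the scatter) and a 3.1-fold lower number from compound 2 to compound 3 (0.49 log units; beyond the scatter), both beyond the scatter, so the anilide is the stronger variant here. Between the two aryl ketones the step of a 1.4-fold lower number from compound 1 to compound 2 (0.15 log units; within the scatter) stays within the scatter.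

Compound 4 `COc1cc(-c2nnc(SCC(=O)Nc3ccccc3F)n2N)cc(OC)c1OC` keeps the anilide of compound 3 and differs only by fluoro in place of hydrogen on an aromatic carbon. Going by the values given here, no measured step exchanges a single substituent on an otherwise fixed aryl group; the closest comparison is a 1.4-fold lower number from compound 1 to compound 2 (0.15 log units; within the scatter), where one halogenated aryl replaces another and the number does not move beyond the scatter. On that basis the step to compound 4 in this assay is expected to be small, a 1.0-fold lower number from compound 3 to compound 4 (0.01 log units; within the scatter), with no direction claimed. Compound 4 is therefore estimated at 1700 nM, within a range of 800 nM to 3700 nM.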

Compound 4, half-maximal inhibitory concentration: 1160 nM
Compound 4: middle estimate off by 1.5-fold (0.17 log units), on the high side; the measured number falls inside the stated range.
By their numbers in this assay, from the lowest: compounds 4 and 3 (each within the scatter of the next); then compounds 2 and 1 (each within the scatter of the next).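

In this assay, going by these compounds alone, fluoro in place of hydrogen on an aromatic carbon, ortho to a large group, gives the first reading of a single substituent added to an otherwise fixed aryl group, and a 1.5-fold lower number from compound 3 to compound 4 (0.17 log units; within the scatter) shows no change that can be told from the scatter. The separation from the aryl ketones persists with the (2-fluorophenyl)amino group, with a 4.6-fold lower number from compound 2 to compound 4 (0.66 log units; beyond the scatter) and a 6.5-fold lower number from compound 1 to compound 4 (0.81 log units; beyond the scatter), both beyond the scatter, so among these four compounds both anilides keep the lower numbers. No evidence on the cause of these steps is available.

On these data alone, whether the fluoro result extends to a larger substituent on the same carbon, such as chloro or methoxy, remains open. Also open, as far as these compounds go, is how the anilide would respond to an amine or a carboxylic acid on its ring, or to a methyl group on the amide nitrogen.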